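A few compounds are considered here, and "the series" means these few. Any claim that something is new, unique, unknown or untested is made for them only; others in the source may bear on it.

Measured so far:
compound 1 `CCCCCc1cn(C/C=C(/C)CCC=C(C)C)nn1` — 5.45
compound 2 `CCCCCCCCc1cn(C/C=C(/C)CCC=C(C)C)nn1` — 6.92
compound 3 `CCCCCc1cn(C/C=C(\C)CC/C=C(\C)CCC=C(C)C)nn1` — 7.5

Among the measured compounds shown here, in a physicochemical assay for lipophilicity, measured as octanol-water partition (on this read-out higher numbers stand for higher lipophilicity and lower numbers for lower lipophilicity), compound 1 stands lowest of the three; compound 2 sits above it by a number 1.47 log units higher from compound 1 to compound 2 (beyond the scatter), and compound 3, for which no single-point step to compound 1 is available, sits higher still on its own value. Compound 4 `CC(C)=CCC/C(C)=C\Cn1cc(-c2ccccc2)nn1` differs from compound 1 by phenyl in place of pentyl on an aromatic carbon. For the measured compounds named here, the only step measured on this series, a number 1.47 log units higher from compound 1 to compound 2 (beyond the scatter), concerns a longer saturated chain and bears on the present change only indirectly: it shows how strongly chain carbons move this assay, but nothing measured covers an aromatic ring replacing a chain. A modest fall, beyond the scatter yet well short of that step, is expected for compound 4, a number 0.55 log units lower from compound 1 to compound 4 (beyond the scatter). Compound 4 is therefore estimated at 4.9, within 4.4 to 5.4.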

Compound 4, partition coefficient: 4.91
The estimate for compound 4 lay 0.01 log units below the measured number; the range from low to high includes it.
By their numbers in this assay, from the lowest: compound 4; then compound 1; then compound 2; then compound 3.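

In this assay the substituent on this aromatic carbon can lower the number as well as raise it: phenyl in place of pentyl gives a number 0.54 log units lower from compound 1 to compound 4 (beyond the scatter), whereas chain extension at the same substituent gave a number 1.47 log units higher from compound 1 to compound 2 (beyond the scatter). The fall comes although phenyl, at 6 heavy atoms, is the larger group by count, so heavy-atom count alone does not order these two groups here. Nothing available explains this fall. On these data alone, it remains open whether a benzyl group or an amine on the phenyl ring would move the number further. As far as these compounds go, whether the same change gives a similar step on the longer tail of compound 3 also remains open.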